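This account rests on a few compounds, and the source may have more. Where it says the series, first, only, none or still open, it means among the compounds named here.

Of the compounds shown here, two sharing one core have so far been tested in a functional assay on HepG2 cells (Homo sapiens) for cytotoxicity, read by MTT assay, with a stated time of 48 h; on this read-out higher numbers stand for weaker inhibition and lower numbers for stronger inhibition. In this test, compound 1 (`Cc1ncc([N+](=O)[O-])n1CCSc1nnc(-c2ccco2)o1`), with a furan-2-yl group, gives 22600 nM, and compound 2 (`Cc1ncc([N+](=O)[O-])n1CCSc1nnc(-c2cccs2)o1`), with a thiophen-2-yl group, gives 20500 nM. Within the data shown here, the only measured step, a 1.1-fold lower number from compound 1 to compound 2 (0.04 log units; within the scatter), places the pair level, so compound 2 stands with its single neighbour on the numbers.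

Compound 3 (`Cc1ncc([N+](=O)[O-])n1CCSc1nnc(-c2ccc(N)nc2)o1`) keeps the core and changes one group, with 6-aminopyridin-3-yl in place of thiophen-2-yl on an aromatic carbon. The measured step offers only partial guidance. That swap exchanged one five-membered aromatic ring for another, while compound 3 brings a six-membered aromatic ring and a hydrogen-bond donor. Among the measured compounds shown here, no measured compound carries such a group, so the direction of any shift cannot be read from the data. For the measured compounds named here, with a 1.1-fold lower number from compound 1 to compound 2 (0.04 log units; within the scatter) as the only guide, the estimated step, a 1.0-fold lower number from compound 2 to compound 3 (0.01 log units; within the scatter), is expected to stay within the scatter, although a wide margin on either side is needed. For compound 3 the estimate is 20000 nM, with an expected range from 8000 nM to 50000 nM.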

Compound 3, half-maximal inhibitory concentration: 9400 nM
Beside the measured number, compound 3's estimate is 2.1-fold (0.33 log units) above it, and the stated range covers the measured number.
By their numbers in this assay, from the lowest: compound 3; then compounds 2 and 1 (each within the scatter of the next).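

At the aromatic carbon of the five-membered ring with 2 nitrogen and 1 oxygen, the exchange of one five-membered aromatic ring for another had left the number within the scatter, so this place could have seemed indifferent to the group it carries. In this assay, the six-membered aromatic ring with its amino group shows otherwise: there is a 2.2-fold lower number from compound 2 to compound 3 (0.34 log units; beyond the scatter) and also a 2.4-fold lower number from compound 1 to compound 3 (0.38 log units; beyond the scatter) in the same direction, both modest but beyond the scatter. Nothing measured here explains this shift, and no supporting data on its cause are available.

The change brings a larger ring, a ring nitrogen and an amino group all at once, so which of them matters remains unresolved, and phenyl or unsubstituted pyridin-3-yl at this place would help to separate these parts. From the compounds shown here alone, it also remains open how the number would respond if the amino group gave way to a dimethylamino group, a hydroxyl group or a carboxylic acid on the same ring.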